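Trimethoxyphenyl in place of phenyl on the imidazolone ring

A few compounds are considered here, and "the series" means these few. Any claim that something is new, unique, unknown or untested is made for them only; others in the source may bear on it.

Measured compounds:
compound 1 `COc1cc(/C=C/C(=O)c2cccc(-n3cc(-c4ccccc4)[nH]c3=O)c2)cc(OC)c1OC` gives 2090 nM
compound 2 `COc1cc(/C=C/C(=O)c2cccc(-n3cc(-c4ccccc4)[nH]c3=O)c2)ccc1O` gives 3310 nM
compound 3 `O=C(/C=C/c1cccc(O)c1)c1cccc(-n2cc(-c3ccc(Cl)cc3)[nH]c2=O)c1` gives 1950 nM

Of the compounds shown here, three sharing one core have been tested in a functional assay on SN12C cells (Homo sapiens) for inhibition; a lower number here means a stronger inhibitor of growth, a higher number a weaker inhibitor of growth. Compound 1 gives 2090 nM, compound 2 gives 3310 nM and compound 3 gives 1950 nM. Compound 1 stands second highest of the three numbers, yet its gaps to compound 3 and to compound 2 both lie within the usual scatter of this assay, so no order among them can be read from these values.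

Compound 4 `COc1cc(/C=C/C(=O)c2cccc(-n3cc(-c4cc(OC)c(OC)c(OC)c4)[nH]c3=O)c2)cc(OC)c1OC` has not yet been measured. It differs from compound 1 in one place: 3,4,5-trimethoxyphenyl in place of phenyl on an aromatic carbon. Among the measured compounds shown here, no measured pair shows this change, so its effect can only be guessed. With nothing in the measured set pointing to a large shift either way, the step from compound 1 to compound 4 is expected to be small, a 1.2-fold higher number from compound 1 to compound 4 (0.08 log units; within the scatter), and possibly within the scatter. Compound 4 is therefore estimated to give about 2500 nM in this assay, with a plausible range from 800 nM to 8000 nM.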

Compound 4, concentration for 50% growth inhibition: 2750 nM
Estimate against measurement, compound 4: 1.1-fold (0.04 log units) below; low and high end bracket the measured number.
By their numbers in this assay, from the lowest: compounds 3, 1, 4 and 2 (each within the scatter of the next).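

Among the compounds shown here, at this position, on an aromatic carbon of a five-membered aromatic ring with 2 nitrogen, the earlier compounds offered no single-place comparison. In this assay the exchange of phenyl for 3,4,5-trimethoxyphenyl gives a 1.3-fold higher number from compound 1 to compound 4 (0.12 log units; within the scatter) and so leaves the two compounds indistinguishable, even though the entering group has 12 heavy atoms against 6 and brings 3 hydrogen-bond acceptors where phenyl has none. No measured property bears on this result.

For the compounds shown here, this single step shows only that this one aryl group is tolerated on the core of compound 1, so it cannot say how far that tolerance extends. From the compounds shown here alone, whether an amine, a carboxylic acid or a longer chain at this position would also stay within the scatter of compound 1 remains open.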